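The source may report more compounds than this note shows. Statements on the series, on what has been measured and on what is new or still open speak of the compounds shown alone.

In a functional assay on SW 1116 cells (Homo sapiens) for antiproliferative activity, read by MTT assay, with a stated time of 24 h (on this read-out higher numbers stand for weaker inhibition and lower numbers for stronger inhibition), compound 1 `COc1cccc(CSc2nnc(-c3ccc4c(c3)OCCO4)n2-c2ccccc2)c1` gives 10100 nM, and compound 2 `Cc1ccccc1CSc1nnc(-c2ccc3c(c2)OCCO3)n1-c1ccccc1` gives 12700 nM. Compound 2 sits alongside compound 1, the two values lying within the scatter of each other, as shown by a 1.3-fold higher number from compound 1 to compound 2 (0.10 log units; within the scatter). Compound 3 `Fc1ccc(CSc2nnc(-c3ccc4c(c3)OCCO4)n2-c2ccccc2)c(F)c1` carries 2,4-difluorophenyl in place of 2-methylphenyl on a saturated chain carbon bound to a sulfur. Going by the values given here, the only measured step that bears on this change is the one between compound 1 and compound 2, and it was small, so in this assay no movement beyond the scatter is expected in either direction. The estimated step is a 1.2-fold lower number from compound 2 to compound 3 (0.06 log units; within the scatter). Compound 3 is therefore expected to give about 11000 nM, with a range from 5000 nM to 25000 nM.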

Compound 3, half-maximal inhibitory concentration: 7830 nM
Compound 3: the middle estimate sits 1.4-fold (0.15 log units) above what was measured, and the stated range covers the measured number.
By their numbers in this assay, from the lowest: compounds 3, 1 and 2 (each within the scatter of the next).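

In this assay, 2,4-difluorophenyl on a saturated chain carbon bound to a sulfur gives a 1.6-fold lower number from compound 2 to compound 3 (0.21 log units; within the scatter) and a 1.3-fold lower number from compound 1 to compound 3 (0.11 log units; within the scatter). Three differently substituted phenyl groups now sit within the scatter of one another at this place, so swapping among them has yet to produce a step beyond it. Nothing available explains these numbers. Still open, as far as these compounds go, is whether a group without a phenyl ring, such as an amine or a carboxylic acid on a longer chain, would move the number beyond the scatter here.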